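This account rests on a few compounds, and the source may have more. Where it says the series, first, only, none or still open, it means among the compounds named here.

Measured so far in a functional assay on HeLa cells (Homo sapiens) for inhibition, read by MTT assay, with a stated time of 72 h; a lower number here means a stronger inhibitor, a higher number a weaker inhibitor:
- compound 1, `CN(C(=O)NC(=O)c1cccc(C(F)(F)F)c1)c1nc(C(F)(F)F)c(C(=O)N/N=C/c2ccccc2C(F)(F)F)s1`: 7.37 ug/mL
- compound 2, `CN(C(=O)NC(=O)c1ccc(C(F)(F)F)cc1)c1nc(C(F)(F)F)c(C(=O)N/N=C/c2ccc(C(F)(F)F)cc2)s1`: > 100 ug/mL (a limit of the assay, not a number)
- compound 3, `CN(C(=O)NC(=O)c1ccccc1F)c1nc(C(F)(F)F)c(C(=O)N/N=C/c2ccccc2C(F)(F)F)s1`: 10.1 ug/mL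

Compound 3 stands as the higher of the two numbers, with compound 1 nearest; the step of a 1.4-fold higher number from compound 1 to compound 3 (0.14 log units; within the scatter) is within the scatter. Compound 2 gives only a limit, (the limit of > 100 ug/mL in this assay, at which 1 of the 3 values shown sits).

Compound 4, `CN(C(=O)NC(=O)c1ccc(C(F)(F)F)cc1)c1nc(C(F)(F)F)c(C(=O)N/N=C/c2ccccc2C(F)(F)F)s1`, has not been measured. It differs from compound 3 as follows: 4-(trifluoromethyl)phenyl in place of 2-fluorophenyl on a carbonyl carbon. For the measured compounds named here, the only measured step on this carbonyl position, a 1.4-fold higher number from compound 1 to compound 3 (0.14 log units; within the scatter), swapped a 3-(trifluoromethyl)phenyl for a 2-fluorophenyl and stayed within the scatter. The 4-(trifluoromethyl)phenyl now entering is the group carried on the carbonyl carbon by compound 2, which is reported only as a limit, so the expectation is uncertain. The step of a 2.5-fold higher number from compound 3 to compound 4 (0.39 log units; beyond the scatter) is expected to run toward a higher number, with a real chance that only a limit is returned. Compound 4 is estimated at 25 ug/mL, in the range 6 ug/mL to 100 ug/mL.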

Compound 4, half-maximal inhibitory concentration: 3.76 ug/mL
Compound 4: middle estimate off by 6.6-fold (0.82 log units), on the high side; the whole stated range lies above it.
By their numbers in this assay, from the lowest: compounds 4, 1 and 3 (each within the scatter of the next, the first and the last beyond it). At a limit, above all of these: compound 2.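

In this assay, for the compounds shown here, the step of a 2.7-fold lower number from compound 3 to compound 4 (0.43 log units; beyond the scatter) is the first change on the carbonyl carbon to go beyond the scatter, while the step of a 2.0-fold lower number from compound 1 to compound 4 (0.29 log units; within the scatter) stays within it, so 3-(trifluoromethyl)phenyl and 4-(trifluoromethyl)phenyl are not separated here. The 4-(trifluoromethyl)phenyl on the carbonyl carbon is therefore compatible with a low number, and the step of an at least 26-fold lower number from compound 2 to compound 4 (1.42 log units; beyond the scatter) comes from 2-(trifluoromethyl)phenyl in place of 4-(trifluoromethyl)phenyl on the carbon with a double bond to nitrogen. Compound 2 gives a limit and not a number: the limit of > 100 ug/mL in this assay, at which 1 of the 4 values shown sits.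

The effect on the carbon with a double bond to nitrogen rests on this single pair, one side of which is a limit. From the compounds shown here alone, how an unsubstituted phenyl, or a phenyl carrying a methoxy group or a carboxylic acid, would read on either position remains open.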